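The source may hold more compounds than are shown below. What is called first, only, known or untested is meant among the compounds shown, and "the series" means these compounds.

In an ADME assay on SW1353 cells (Homo sapiens) for cytotoxicity, read by a luciferase reporter, with a stated time of 30 min (on this read-out lower numbers stand for higher toxicity in this test and higher numbers for lower toxicity in this test), compound 1 (`O=C(Nc1ccc(N2CCNCC2)cc1)c1ccc(-c2ccc(Cl)s2)o1`) reads > 20000 nM here, which is a limit of the assay and not a number. Compound 2 (`O=C(Nc1ccc(N2CCNCC2)cc1C(F)(F)F)c1ccc(-c2ccc(Cl)cc2)o1`) gives 18000 nM as its value. From the compounds shown here alone, compound 3 (`O=C(Nc1ccc(N2CCC(O)CC2)cc1)c1ccc(-c2ccc(Cl)cc2)o1`) has no number at all ("not determined" (no result reported)), so its place on this scale is unknown. Compound 4 (`O=C(Nc1ccc(C2=CCNCC2)cc1)c1ccc(-c2ccc(Cl)cc2)o1`) is still unmeasured. The change a group of 6 heavy atoms (5 carbon, 1 nitrogen; one six-membered non-aromatic ring with 1 hetero atom) in place of a group of 7 heavy atoms (5 carbon, 1 nitrogen, 1 oxygen; one six-membered non-aromatic ring with 1 hetero atom), on an aromatic carbon brings in a ring with a double bond in place of the 4-hydroxypiperidin-1-yl group, on an aromatic carbon. With no value for compound 3, the size of this step cannot be read directly. In this assay, a result within the usual scatter of compound 2 at 18000 nM is expected, which would still mean low toxicity. Compound 4 is estimated at 16000 nM (expected range 7000 nM to 20000 nM).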

Compound 4, half-maximal cytotoxic concentration: 6500 nM
Compound 4: middle estimate off by 2.5-fold (0.39 log units), on the high side; measured number outside the range, below it.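

Among these compounds, compound 3 has no reported result, so no step from it to compound 4 can be read. Still open, from the compounds shown here alone, is whether replacing the 4-hydroxypiperidin-1-yl group with the double-bond ring shifts the reading in this assay at all.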